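From methylamino to dimethylamino in the series

This account rests on a few compounds, and the source may have more. Where it says the series, first, only, none or still open, it means among the compounds named here.

Measured in an ADME assay on CHO cells (Cricetulus griseus) for cytotoxicity; on this read-out higher numbers stand for weaker inhibition and lower numbers for stronger inhibition:
- compound 1 `N#Cc1cc(=O)[nH]c(=O)n1[C@@H]1O[C@H](CO)[C@@H](O)[C@H]1O`: > 1500000 nM (a limit)
- compound 2 `Nc1cc(=O)[nH]c(=O)n1[C@@H]1O[C@H](CO)[C@@H](O)[C@H]1O`: > 1500000 nM (a limit)
- compound 3 `CNc1cc(=O)[nH]c(=O)n1[C@@H]1O[C@H](CO)[C@@H](O)[C@H]1O`: 71900 nM

In this assay, within the data shown here, compound 3 gives 71900 nM, the only actual number so far. The other two entries stand at the limit of > 1500000 nM in this assay, at which 2 of the 3 values shown sit.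

Compound 4 `CN(C)c1cc(=O)[nH]c(=O)n1[C@@H]1O[C@H](CO)[C@@H](O)[C@H]1O` differs from compound 3 by methyl in place of hydrogen on a nitrogen on an aromatic ring, that is, methylamino to dimethylamino.

Among the measured compounds shown here, the closest precedent is the same kind of change, methyl in place of hydrogen on a nitrogen on an aromatic ring: an at least 20-fold lower number from compound 2 to compound 3 (1.31 log units; beyond the scatter). A different change, methylamino in place of cyano on an aromatic carbon, gives an at least 20-fold lower number from compound 1 to compound 3 (1.31 log units; beyond the scatter). Amino in place of cyano on an aromatic carbon gives a step that the two limits leave unreadable from compound 1 to compound 2.

With a single precedent that starts from a limit, a further fall in the number is expected in this assay, but a smaller one than an at least 20-fold lower number from compound 2 to compound 3 (1.31 log units; beyond the scatter). The expected move is a 2.4-fold lower number from compound 3 to compound 4 (0.38 log units; beyond the scatter). For compound 4 the estimate is 30000 nM, with an expected range of 5000 nM to 200000 nM.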

Compound 4, half-maximal inhibitory concentration: 68300 nM
Compound 4: the middle estimate sits 2.3-fold (0.36 log units) below what was measured; the measured number falls inside the stated range.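

In this assay a second methyl on the nitrogen gives a 1.1-fold lower number from compound 3 to compound 4 (0.02 log units; within the scatter) and thus does not repeat the first methyl, which gave an at least 20-fold lower number from compound 2 to compound 3 (1.31 log units; beyond the scatter) on the same nitrogen. Dimethylamino keeps its distance from the amino and cyano compounds, with an at least 21-fold lower number from compound 2 to compound 4 (1.34 log units; beyond the scatter) and an at least 21-fold lower number from compound 1 to compound 4 (1.34 log units; beyond the scatter) on this aromatic carbon. Both of these steps are bounds and not sizes because each starts from a limit: the limit of > 1500000 nM in this assay, at which 2 of the 4 values shown sit.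

Left open is whether a longer chain on this nitrogen, such as ethylamino, or a ring amine such as pyrrolidine, stays level with compound 3 and compound 4 or moves the number again. On these data alone, compound 2 carries only a limit, and the real size of the first methyl step stays open.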